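Removing a hydroxy from compound 2

The compounds below may be only part of what the source reports. "The series", "measured", "known", "first", "only" and "open" are said of these compounds alone.

Measured compounds in a functional assay, read by spectrophotometry, with a stated time of 30 min, tested at 100 uM; a higher number here means a stronger effect of the compound at the concentration tested, a lower number a weaker effect:
compound 1, `COc1cc(/C=C/c2nc3cc(Cl)cnc3n(CC(=O)O)c2=O)ccc1O`, gives 94.9%
compound 2, `COc1c(O)cc(-c2nc3cccnc3n(CC(=O)O)c2=O)cc1O`, gives 45.6%

Going by the values given here, compound 2 stands lowest of the two numbers known here. Among the compounds with values here, the only other compound measured, compound 1, lies far above it, and that gap is beyond the usual scatter of the measurement. Within the data shown here, compound 1 and compound 2 differ in more than one place, so no single step between them can be drawn, and the two values are all that can be said of that pair.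

Compound 3 is `COc1ccc(-c2nc3cccnc3n(CC(=O)O)c2=O)cc1O`. It is not yet measured. It differs from compound 2 in one place: hydrogen in place of hydroxy on an aromatic carbon. The change is small, a single heavy atom leaving, and nothing in the two measured compounds shows what a hydroxy at this place contributes.

For this reason the step from compound 2 to compound 3 is expected to be small, likely within the scatter, and is estimated as a number 0.6 percentage points lower from compound 2 to compound 3 (within the scatter). Compound 3 is estimated to give 45%, within a range of 20% to 75%.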

Compound 3, a percentage reported as activity, at one concentration (the size of the read-out at that concentration, not a potency): 32.1%
Estimate against measurement, compound 3: 12.9 percentage points above; the measured number falls inside the stated range.
By their numbers in this assay, from the lowest: compound 3; then compound 2; then compound 1.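

In this assay, the hydroxy on this aromatic carbon, ortho to a methoxy group and meta to a large group, can now be judged on its own: putting hydrogen in its place gives a number 13.5 percentage points lower from compound 2 to compound 3 (beyond the scatter). The two earlier compounds could not show this, and the step shows that this hydroxy is not idle in the read-out, although the change is modest and compound 3 still gives 32.1% without it. No measurement at hand bears on why the number falls with this single change.

From the compounds shown here alone, it remains open whether another group on this same carbon, such as an amine or a fluorine atom, would hold the number of compound 2, lower it further or raise it. Also open, going by these compounds, are what the remaining hydroxy of compound 3 contributes and whether the step from removing this hydroxy would keep its size on a differently substituted core such as that of compound 1.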